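The source may hold more compounds than are shown below. What is called first, only, known or untested is meant among the compounds shown, and "the series" means these compounds.

Compound 1 `Fc1cccc(-c2nc(Nc3ccc(Cl)cc3)c3cc(F)ccc3n2)c1`: 45700 nM
Compound 2 `Fc1cccc(-c2nc(Nc3cccc(Cl)c3)c3cc(F)ccc3n2)c1`: > 50000 nM

Both compounds were tested in a functional assay on HL-60 cells (Homo sapiens) for cytotoxicity, read by MTT assay, with a stated time of 48 h; a higher number here means a weaker inhibitor, a lower number a stronger inhibitor. Compound 1 gives a measured number in this assay. Compound 2 reaches only a limit of the assay, so no true number is known for it, and its reading of > 50000 nM marks that ceiling. Putting 3-chlorophenyl in place of 4-chlorophenyl on the nitrogen on the aromatic ring gives an at least 1.0-fold higher number from compound 1 to compound 2 (0.03 log units; that floor lies within the scatter), a step that lies within the scatter and is capped by the limit of > 50000 nM in this assay, at which 1 of the 2 values shown sits.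

Compound 3 `Fc1cccc(-c2nc(Nc3ccc(Br)cc3)c3cc(F)ccc3n2)c1` has not yet been measured. It differs from compound 2 by 4-bromophenyl in place of 3-chlorophenyl on a nitrogen on an aromatic ring. Going by the values given here, the only measured step that bears on this change is the one from compound 1 to compound 2, which was too small to separate from noise, so a halogen moving around this phenyl ring gave no clear shift so far. Compound 3 is therefore expected to stay near the same weak level, with an at least 1.1-fold lower number from compound 2 to compound 3 (0.04 log units; that floor lies within the scatter) expected. Compound 3 is estimated at 45000 nM, in a range from 20000 nM to 100000 nM, and a limit reading is again quite possible.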

Compound 3, half-maximal inhibitory concentration: > 50000 nM
Compound 3: a limit, no number (the forecaster's own chance of this, stated with the estimate: 45%); middle value at least 1.1-fold (0.04 log units) away from the limit.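

Bromo in place of chloro on an aromatic carbon gives an at least 1.0-fold higher number from compound 1 to compound 3 (0.03 log units; that floor lies within the scatter), so exchanging the halogen itself, and not only moving it around the phenyl ring, brings no stronger reading in this assay. The step from compound 2 to compound 3 cannot be read, since both ends of it are limits and not numbers. Across these three compounds, compound 1 is the only one with a true number, and the other two rest at the end of what the test can report: the limit of > 50000 nM in this assay, at which 2 of the 3 values shown sit.

Where the true numbers of compound 2 and compound 3 lie stays open, so any real difference among the three compounds at this weak level cannot yet be told. Also open, on these data alone, is whether a group of another kind on this phenyl ring, such as an amine, a carboxylic acid or a methoxy group, would bring the number in this assay clearly down from the level of compound 1.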